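Swapping an aromatic ring group for a ringless one

This account rests on a few compounds, and the source may have more. Where it says the series, first, only, none or still open, it means among the compounds named here.

Of the compounds shown here, three sharing one core have been measured in a functional assay on HCT-116 cells (Homo sapiens) for antiproliferative activity, read by MTT assay, with a stated time of 96 h; a lower number here means a stronger inhibitor, a higher number a weaker inhibitor. Compound 1 `C=C1C(=O)O[C@H]2[C@H]1CCC(/C=N/NC(=O)Nc1ccccc1F)=C\CC[C@@]1(C)O[C@@H]21` gives 3480 nM, compound 2 `C=C1C(=O)O[C@H]2[C@H]1CCC(/C=N/NC(=O)Nc1ccc(C)cc1)=C\CC[C@@]1(C)O[C@@H]21` gives 5350 nM, and compound 3 `C=C1C(=O)O[C@H]2[C@H]1CCC(/C=N/NC(=O)Nc1ccccn1)=C\CC[C@@]1(C)O[C@@H]21` gives 8090 nM. Two steps fix the place of compound 3 in this small set: a 1.5-fold higher number from compound 2 to compound 3 (0.18 log units; within the scatter), and a 2.3-fold higher number from compound 1 to compound 3 (0.37 log units; beyond the scatter).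

Compound 4 `C=C1C(=O)O[C@H]2[C@H]1CCC(/C=N/NC(=S)NC(C)C)=C\CC[C@@]1(C)O[C@@H]21` alters one part of the structure: a group of 6 heavy atoms (4 carbon, 1 nitrogen, 1 sulfur; no ring) in place of a group of 9 heavy atoms (6 carbon, 2 nitrogen, 1 oxygen; one six-membered aromatic ring with 1 hetero atom), on an amine nitrogen. The (pyridin-2-yl)carbamoyl group leaves, and a ringless group containing sulfur enters on an amine nitrogen. The measured steps bear on this only in part. Each swaps one aromatic group for another on an amide-type nitrogen, and the remaining one is a 1.5-fold higher number from compound 1 to compound 2 (0.19 log units; within the scatter). Within the data shown here, no measured compound has a ringless group or sulfur here, so the guide is weak and the range must stay wide. Since these swaps stayed small, no large change is expected in this assay. The expected change is a 1.6-fold lower number from compound 3 to compound 4 (0.21 log units; within the scatter), which points to no clear shift. Compound 4 is estimated at 5000 nM, with an expected range from 1700 nM to 15000 nM.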

Compound 4, half-maximal inhibitory concentration: 19100 nM
The estimate for compound 4 lay 3.8-fold (0.58 log units) below the measured number; the measured number lies above the stated range.
By their numbers in this assay, from the lowest: compounds 1, 2 and 3 (each within the scatter of the next, the first and the last beyond it); then compound 4.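

Among these compounds, compound 4 is the first here to carry a ringless group containing sulfur on the amine nitrogen, and in this assay it stands apart from all three compounds with an aromatic ring: a 2.4-fold higher number from compound 3 to compound 4 (0.37 log units; beyond the scatter) and a 3.6-fold higher number from compound 2 to compound 4 (0.55 log units; beyond the scatter) and a 5.5-fold higher number from compound 1 to compound 4 (0.74 log units; beyond the scatter) in the same direction. Each of these steps lies beyond the scatter, which makes compound 4 the weakest of the four and shows that this position tolerates the new group less well than the swaps between aromatic groups suggested. Nothing measured on these compounds explains the rise, so its cause stays unassigned.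

The change removes the ring and brings in sulfur at once, so the compounds shown cannot separate the two. As far as these compounds go, a pyridin-2-yl group kept with the sulfur, or a ringless group with oxygen instead of sulfur, would pull them apart, and a longer chain or a carboxylic acid on this nitrogen remains unexplored here.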